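Pyrazoline series: aryl swap on the saturated ring carbon

A few compounds are considered here, and "the series" means these few. Any claim that something is new, unique, unknown or untested is made for them only; others in the source may bear on it.

Two compounds of the shared core have numbers in a functional assay on Caco-2 cells (Homo sapiens) for antiproliferative activity, read by MTT assay, with a stated time of 24 h; a higher number here means a weaker inhibitor, a lower number a stronger inhibitor. Compound 1 `c1ccc(C2=NN(c3ccc(-c4ccccc4)nn3)C(c3ccccc3)C2)cc1` gives 40900 nM; compound 2 `FC(F)(F)c1ccc(C2CC(c3ccccc3)=NN2c2ccc(-c3ccccc3)nn2)cc1` gives 50000 nM. Compound 2 stands highest of the two, but the step of a 1.2-fold higher number from compound 1 to compound 2 (0.09 log units; within the scatter) is within the scatter, so the two are not separated.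

Compound 3 `COc1ccc(C2CC(c3ccccc3)=NN2c2ccc(-c3ccccc3)nn2)c(OC)c1` differs from compound 2 by 2,4-dimethoxyphenyl in place of 4-(trifluoromethyl)phenyl on a saturated ring carbon. Among the compounds with values here, the only measured step at this position, from compound 1 to compound 2, exchanges hydrogen for trifluoromethyl and is within the scatter; no measured step covers methoxy groups, so nothing in this assay speaks for a shift in either direction. The expectation for compound 3 in this assay is therefore a step of a 1.1-fold lower number from compound 2 to compound 3 (0.05 log units; within the scatter), not beyond the scatter. Compound 3 is estimated at 45000 nM, with a range from 15000 nM to 100000 nM.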

Compound 3, half-maximal inhibitory concentration: > 100000 nM
Compound 3 gave a limit, no number; the forecaster's own chance of this, stated with the estimate: 30%; at least 2.2-fold (0.34 log units) between middle value and limit.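

In this assay compound 3 gives no number, only a limit of the assay: the limit of > 100000 nM in this assay, at which 1 of the 3 values shown sits. Even so, 2,4-dimethoxyphenyl in place of phenyl on the saturated ring carbon gives an at least 2.4-fold higher number from compound 1 to compound 3 (0.38 log units; beyond the scatter), the first step at this position that lies beyond the scatter, so the position does respond to a change of aryl group. Measured against 4-(trifluoromethyl)phenyl, the step is an at least 2.0-fold higher number from compound 2 to compound 3 (0.30 log units; that floor lies within the scatter), and that floor alone does not separate the two compounds, while the full size of both steps stays hidden behind the limit.

Going by these compounds, whether one methoxy group alone carries the step, or both are needed, stays open. Also open, on these data alone, is how an amine or a carboxylic acid on this aryl ring would read in the same assay.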